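The source may hold more compounds than are shown below. What is called first, only, known or untested is meant among the compounds shown, and "the series" means these compounds.

Compound 1, `Cc1cc(C)c(Oc2cc(Nc3ccc(C#N)cc3)ncc2C(=O)NCc2cn(Cc3ccc(F)cc3)nn2)c(C)c1`, in an ADME assay on MT4 cells (Homo sapiens) for cytotoxicity, read by MTT assay, with a stated time of 5 days (a lower number here means that less compound is tolerated, a higher number that more compound is tolerated), gives >= 153000 nM, which is a limit of the assay and not a number.
Compound 2, `Cc1cc(C)c(Oc2cc(Nc3ccc(C#N)cc3)ncc2C(=O)NCc2cn(CC(=O)N3CCOCC3)nn2)c(C)c1`, in this assay gives 181000 nM.
Compound 3, `COC(=O)Cn1cc(CNC(=O)c2cnc(Nc3ccc(C#N)cc3)cc2Oc2c(C)cc(C)cc2C)nn1`, in this assay gives 13800 nM.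

Compound 3 therefore holds the lowest of the two numbers shown; its nearest neighbour is compound 2, and the gap is a 13-fold lower number from compound 2 to compound 3 (1.12 log units; beyond the scatter). Compound 4, `Cc1cc(C)c(Oc2cc(Nc3ccc(C#N)cc3)ncc2C(=O)NCc2cn(CCC#N)nn2)c(C)c1`, differs from compound 3 in one place: cyanomethyl in place of methoxycarbonyl on a saturated chain carbon bound to an aromatic nitrogen. Going by the values given here, two measured steps bear on the methoxycarbonyl group that leaves. From compound 1, where a 4-fluorophenyl stood at that position, the step was an at least 11-fold lower number from compound 1 to compound 3 (1.04 log units; beyond the scatter); from compound 2 the step was a 13-fold lower number from compound 2 to compound 3 (1.12 log units; beyond the scatter). Both show the methoxycarbonyl group going with a much lower number, so its removal is expected to raise the number again, even though the entering cyanomethyl group has no measured counterpart among these compounds. Compound 4 is thus estimated to give 80000 nM, within 25000 nM to 200000 nM. The expected step is a 5.8-fold higher number from compound 3 to compound 4 (0.76 log units; beyond the scatter).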

Compound 4, half-maximal cytotoxic concentration: 40200 nM
Estimate against measurement, compound 4: 2.0-fold (0.30 log units) above; low and high end bracket the measured number.
By their numbers in this assay, from the lowest: compound 3; then compound 4; then compound 2.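

Cyanomethyl in place of methoxycarbonyl raises the number in this assay (a 2.9-fold higher number from compound 3 to compound 4 (0.46 log units; beyond the scatter)), but only part of the way, as it stays lower than with (morpholin-4-yl)carbonyl (a 4.5-fold lower number from compound 2 to compound 4 (0.65 log units; beyond the scatter)). It also stays lower than with 4-fluorophenyl (an at least 3.8-fold lower number from compound 1 to compound 4 (0.58 log units; beyond the scatter)), so this position gives an intermediate value and not just two levels. Compound 1 stands at a limit, so that last step is only a bound and its step to compound 2 cannot be read: (the limit of >= 153000 nM in this assay, at which 1 of the 4 values shown sits).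

Where a carboxylic acid, an amine or a longer chain would fall at this place remains open. So does whether the nitrile or the methoxycarbonyl alone sets the gap.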